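The compounds below may be only part of what the source reports. "The series", "measured", "known", "first", "only" and "open" are said of these compounds alone.

In a functional assay on brain (Rattus norvegicus, strain Wistar) for inhibition (on this read-out lower numbers stand for stronger inhibition and higher numbers for weaker inhibition), compound 1 `Cc1[nH]c(=O)n(C)c1-c1ccc(OC(C)C)cc1` gives 20400 nM and compound 2 `CCCCCCCCc1ccc(-c2c(C)[nH]c(=O)n2C)cc1`, which bears an octyl chain, gives 19400 nM, so these two values lie close together. Compound 3 `Cc1[nH]c(=O)n(C2CCCCC2)c1-c1ccc(OC(C)C)cc1` gives 13000 nM, within the scatter of both. Going by the values given here, the only measured step leading to it, a 1.6-fold lower number from compound 1 to compound 3 (0.20 log units; within the scatter), is cyclohexyl in place of methyl on an aromatic nitrogen, and it too stays within the scatter.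

Compound 4 `CCCCCCOc1ccc(-c2c(C)[nH]c(=O)n2C2CCCCC2)cc1` is made from compound 3 by one change, hexyl in place of isopropyl on an oxygen on an aromatic ring. Among the compounds with values here, no measured step covers a change at this place, so the step on nitrogen bears on it only indirectly. Within the data shown here, the one compound with a long chain, compound 2 at 19400 nM, shows no separation from compound 1 at 20400 nM. No change beyond the scatter is therefore expected, though a modest drop is possible, and the estimated step is a 1.3-fold lower number from compound 3 to compound 4 (0.11 log units; within the scatter). Compound 4 is expected at about 10000 nM, within an estimated range of 3500 nM to 25000 nM.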

Compound 4, half-maximal inhibitory concentration: 8500 nM
Compound 4: middle estimate off by 1.2-fold (0.07 log units), on the high side; the range from low to high includes it.
By their numbers in this assay, from the lowest: compounds 4, 3, 2 and 1 (each within the scatter of the next, the first and the last beyond it).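

Going by these compounds alone, at the oxygen on an aromatic ring, the step from isopropyl to hexyl (a 1.5-fold lower number from compound 3 to compound 4 (0.18 log units; within the scatter)) is the first measured change at this place in this assay, and it stays within the scatter. With cyclohexyl held on the aromatic nitrogen, going from isopropoxy to hexyloxy, with 6 heavy atoms entering where 3 leave, thus gives no separation between the two compounds. No available evidence bears on this result.

The compounds shown leave open whether a decyl chain, an amine or a carboxylic acid in place of hexyl would move the number beyond the scatter. They also leave open whether the same change on the oxygen would give a similar step with methyl rather than cyclohexyl on the aromatic nitrogen.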